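Bromo added to the aryl ether of compound 2

The source may report more compounds than this note shows. Statements on the series, on what has been measured and on what is new or still open speak of the compounds shown alone.

Compound 1 `CCCCCCc1nc2ccccc2[nH]1` gives 32400 nM in an ADME assay on microsomes from liver for inhibition of cytochrome P450 2B1 (Rattus norvegicus); a higher number here means a weaker inhibitor, a lower number a stronger inhibitor. Compound 2 `Brc1ccccc1OCc1nc2ccccc2[nH]1` gives 12000 nM in this assay. Compound 3 `Brc1ccc(OCc2nc3ccccc3[nH]2)c(Br)c1` gives 11000 nM in this assay.

Compound 2 holds the second highest of the three numbers. Its nearest neighbour is compound 3, reached by a 1.1-fold lower number from compound 2 to compound 3 (0.04 log units; within the scatter); its furthest is compound 1, whose number is higher and beyond the scatter. Compound 4 `Brc1cccc(Br)c1OCc1nc2ccccc2[nH]1` differs from compound 2 by bromo in place of hydrogen on an aromatic carbon. Within the data shown here, the only measured step that bears on this change is a 1.1-fold lower number from compound 2 to compound 3 (0.04 log units; within the scatter), also a bromo in place of hydrogen on the same ring, and it stayed within the scatter. No step beyond the scatter is therefore expected in this assay for the change from compound 2 to compound 4, which is expected to be a 1.1-fold lower number from compound 2 to compound 4 (0.04 log units; within the scatter). Compound 4 is estimated at 11000 nM, within 5000 nM to 25000 nM.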

Compound 4, half-maximal inhibitory concentration: 11000 nM
The estimate for compound 4 equals the measured number at the digits printed, and the stated range covers the measured number.
By their numbers in this assay, from the lowest: compounds 3, 4 and 2 (each within the scatter of the next); then compound 1.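

In this assay, bromo in place of hydrogen ortho to a large group and meta to a bromo group gives a 1.1-fold lower number from compound 2 to compound 4 (0.04 log units; within the scatter). Together with a 1.1-fold lower number from compound 2 to compound 3 (0.04 log units; within the scatter), this means that a second bromo at either of two carbons of this ring leaves the number within the scatter. No measured evidence bears on this result. From the compounds shown here alone, whether an amine or a carboxylic acid at this position would give a step beyond the scatter remains open, as does the outcome with a smaller halogen such as fluoro.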